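The source may report more compounds than this note shows. Statements on the series, on what has been measured and on what is new or still open speak of the compounds shown alone.

Measured in an assay on isolated protein for inhibition of ATP-citrate synthase (Rattus norvegicus); a lower number here means a stronger inhibitor, a higher number a weaker inhibitor:

Compound 1 `O=C(O)CC(O)(CSCCCCCCc1cccc(Cl)c1Cl)C(=O)O`, in this assay 7300 nM
Compound 2 `O=C(O)CC(O)(CSCCCCCCc1ccc(Cl)c(Cl)c1)C(=O)O`, in this assay 110000 nM
Compound 3 `O=C(O)CC(O)(CSCCCCCSc1ccc(Cl)cc1Cl)C(=O)O`, in this assay 10000 nM

Compound 2 stands highest of the three numbers in this assay, beyond the scatter from both compound 3 and compound 1. Going by the values given here, the one step that changes only one place, from compound 1 to compound 2, is a 15-fold higher number from compound 1 to compound 2 (1.18 log units; beyond the scatter), a large step from a change of substitution pattern on the same ring. Compound 3 differs from compound 2 in more than one place, so its value only shows that it sits with compound 1 rather than with compound 2.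

Compound 4 `O=C(O)CC(O)(CSCCCCCCc1ccc(F)cc1)C(=O)O` is not yet measured. It differs from compound 2 as follows: 4-fluorophenyl in place of 3,4-dichlorophenyl on a saturated chain carbon, six bonds along the chain from a sulfur. Among the compounds with values here, the step from compound 1 to compound 2 shows that rearranging the chlorines on this ring moves this assay by a large amount, so the ring pattern matters; no measured step shows what a single fluorine does. Since compound 2 is the outlier among the three, the expectation is that compound 4 moves back toward compound 1 and compound 3, an expected step of a 3.7-fold lower number from compound 2 to compound 4 (0.56 log units; beyond the scatter). Compound 4 is estimated at 30000 nM in this assay, with a range from 8000 nM to 120000 nM.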

Compound 4, inhibition constant: 120000 nM
Compound 4: the middle estimate sits 4.0-fold (0.60 log units) below what was measured; low and high end bracket the measured number.
By their numbers in this assay, from the lowest: compounds 1 and 3 (each within the scatter of the next); then compounds 2 and 4 (each within the scatter of the next).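

In this assay, the change from 3,4-dichlorophenyl to 4-fluorophenyl on this saturated chain carbon gives a 1.1-fold higher number from compound 2 to compound 4 (0.04 log units; within the scatter), so these two rings cannot be told apart here, although one carries two chlorines and the other a single fluorine. Set against the 2,3-dichlorophenyl ring, the same 4-fluorophenyl gives a 16-fold higher number from compound 1 to compound 4 (1.22 log units; beyond the scatter), a large step like a 15-fold higher number from compound 1 to compound 2 (1.18 log units; beyond the scatter), which leaves 2,3-dichlorophenyl as the only one of the three rings at this place that stands apart from the others. No measurement at hand accounts for this difference between the rings.

Still open, as far as these compounds go, is where an unsubstituted phenyl, a 4-chlorophenyl or a pyridine ring would fall at this place, and so whether the separation follows the 2,3-dichloro pattern specifically or extends to other rings. Also open, from the compounds shown here alone, is whether the gap between 2,3-dichlorophenyl and the other two rings holds on a shorter or longer chain, or with an oxygen in place of the chain sulfur.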